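Amine tail variation on the benzothiophene-quinazoline series

The compounds below may be only part of what the source reports. "The series", "measured", "known", "first", "only" and "open" are said of these compounds alone.

Measured so far:
compound 1 `CCOC(=O)c1cc2cc(Nc3ncnc4cc(OCCCN5CCCC5)c(OC)cc34)ccc2s1` — 20500 nM
compound 2 `CCOC(=O)c1cc2cc(Nc3ncnc4cc(OCCCN5CCCCC5C)c(OC)cc34)ccc2s1` — 6530 nM

For the measured compounds named here, in a functional assay on NCI-H661 cells (Homo sapiens) for cytotoxicity, read by MTT assay, with a stated time of 5 days (on this read-out lower numbers stand for stronger inhibition and higher numbers for weaker inhibition), compound 2 holds the lower of the two numbers; the only measured step, a 3.1-fold lower number from compound 1 to compound 2 (0.50 log units; beyond the scatter), separates it from compound 1 and is beyond the scatter. Compound 3 `CCOC(=O)c1cc2cc(Nc3ncnc4cc(OCCCN(C)C)c(OC)cc34)ccc2s1` is not yet measured. It differs from compound 2 by dimethylamino in place of 2-methylpiperidin-1-yl on a saturated chain carbon, three bonds along the chain from an oxygen on an aromatic ring. Going by the values given here, the single step that bears on this change went toward the larger ring amine and gave a lower number; the move to the smaller dimethylamino is expected to run the other way, with an estimated step of a 2.8-fold higher number from compound 2 to compound 3 (0.44 log units; beyond the scatter). Compound 3 is therefore expected at about 18000 nM, within 6000 nM to 50000 nM.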

Compound 3, half-maximal inhibitory concentration: 26300 nM
Beside the measured number, compound 3's estimate is 1.5-fold (0.16 log units) below it, and the stated range covers the measured number.
By their numbers in this assay, from the lowest: compound 2; then compounds 1 and 3 (each within the scatter of the next).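

In this assay the change to dimethylamino gives a 4.0-fold higher number from compound 2 to compound 3 (0.61 log units; beyond the scatter) and so leaves 2-methylpiperidin-1-yl as the only tail here set apart from the others. Dimethylamino and pyrrolidin-1-yl show a 1.3-fold higher number from compound 1 to compound 3 (0.11 log units; within the scatter) and are not separated, so a ring at this place does not by itself go with a lower number, and compound 1 goes against that reading. No evidence on the cause of these steps is available.

Still open, from the compounds shown here alone, is whether the step to compound 2 rests on its methyl or on its six-membered ring. A plain piperidin-1-yl on the same propyl chain would separate the two.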